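The source may report more compounds than this note shows. Statements on the series, on what has been measured and on what is new or still open speak of the compounds shown alone.

In a functional assay on the whole organism for inhibition, with Mus musculus as the target (a lower number here means that less compound is needed, a higher number that more compound is needed for the effect), three compounds sharing one core have been measured. Compound 1 `Cc1ccc(C2CN(C)Cc3c(N)cccc32)cc1` gives about 1.2 mg/kg, compound 3 `CCCCNC(=O)Nc1cccc2c1CN(C)CC2c1ccc(Cl)cc1` gives 15 mg/kg, and compound 2 `CCNC(=O)Nc1cccc2c1CN(C)CC2c1ccccc1` gives 54 mg/kg. That last number is the highest of the three, so compound 2 needs the most material for the effect. Compound 4 `CCCCNCCC(=O)Nc1cccc2c1CN(C)CC2c1ccccc1`, not yet measured, keeps the core of compound 2 but carries 2-(butylamino)ethyl in place of ethylamino on a carbonyl carbon. Going by the values given here, no measured pair shows this change, so the expectation stays close to compound 2 at 54 mg/kg. The expected step, a 1.5-fold lower number from compound 2 to compound 4 (0.19 log units; within the scatter), is a slight fall that stays within the scatter. For compound 4 the estimated value is 35 mg/kg, with an expected range from 10 mg/kg to 110 mg/kg.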

Compound 4, dose for half-maximal effect: 74 mg/kg
The estimate for compound 4 lay 2.1-fold (0.33 log units) below the measured number; the range from low to high includes it.
By their numbers in this assay, from the lowest: compound 1; then compound 3; then compounds 2 and 4 (each within the scatter of the next).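

In this assay, putting 2-(butylamino)ethyl in place of ethylamino on a carbonyl carbon gives a 1.4-fold higher number from compound 2 to compound 4 (0.14 log units; within the scatter). Going by these compounds alone, this is the first comparison here of compounds that differ in one place, and even this larger group leaves the number within the scatter, so the swap shows no measurable effect. Nothing available explains this result. On these data alone, whether a carboxylic acid or a piperidine at the end of the chain would shift the number remains open. So does whether a much longer chain would.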